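Halogen Swap on an Aryl Carbamate: Chloro for Bromo

The source may report more compounds than this note shows. Statements on the series, on what has been measured and on what is new or still open speak of the compounds shown alone.

Measured compounds:
compound 1, `C=C1C(=O)OC[C@@H]1CCOC(=O)Nc1ccc(Br)cc1`: 19800 nM
compound 2, `C=C1C(=O)OC[C@H]1CCOC(=O)Nc1c(C)cccc1C(C)C`: 22200 nM
compound 3, `C=C1C(=O)OC[C@H]1CCOC(=O)Nc1cc(C)cc(C)c1`: 12700 nM

The three share one core and differ only in the aryl carbamate. In an ADME assay on RAW264.7 cells (Mus musculus) for cytotoxicity, read by MTT assay, with a stated time of 18 h (a lower number here means that less compound is tolerated, a higher number that more compound is tolerated), compound 1 gives 19800 nM, the second highest of the three numbers; compound 2 gives 22200 nM and compound 3 gives 12700 nM, both within the usual scatter of compound 1, so no order among them can be read. Compound 4 `C=C1C(=O)OC[C@@H]1CCOC(=O)Nc1ccc(Cl)cc1` has not yet been measured in this assay. It differs from compound 1 as follows: chloro in place of bromo on an aromatic carbon. No pair of measured compounds differs in one place, so no shown step guides this change. The step expected here is a 1.1-fold higher number from compound 1 to compound 4 (0.05 log units; within the scatter), nothing beyond the scatter. The estimate for compound 4 is 22000 nM, with a range from 10000 nM to 45000 nM.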

Compound 4, half-maximal cytotoxic concentration: 10300 nM
Estimate against measurement, compound 4: 2.1-fold (0.33 log units) above, within the range that was stated.
By their numbers in this assay, from the lowest: compounds 4, 3, 1 and 2 (each within the scatter of the next, the first and the last beyond it).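

For the compounds shown here, compound 4 supplies the first comparison across a single change: in this assay, chloro in place of bromo on an aromatic carbon, para to a large group, gives a 1.9-fold lower number from compound 1 to compound 4 (0.28 log units; within the scatter) as the only step that can be read. This step stays within the scatter, so this position does not separate the two halogens in this read-out. No measured evidence bears on the step or offers an account of it. The compounds shown leave open whether an amine, a carboxylic acid or a methoxy group at this same place would give a step beyond the scatter.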